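The compounds below may be only part of what the source reports. "The series", "measured", "known", "first", "only" and "open" are said of these compounds alone.

Measured compounds in a functional assay on the whole organism (strain Wistar) for inhibition, with Rattus norvegicus as the target, read by paw edema, with stated times of 30 min and 3 h, at a dose of 100 mg/kg by the oral route; on this read-out lower numbers stand for less inhibition and higher numbers for more inhibition at the one dose given (going by the name of the read-out):
compound 1 `CNC(=O)c1cc(OC)n(-c2ccccc2)n1` — 57.9%
compound 2 `COc1cc(C(=O)Nc2cccc(C(F)(F)F)c2)nn1-c1ccccc1` — 20.9%
compound 3 `CCCCOc1cc(C(=O)NC)nn1-c1ccccc1` — 65%

Compound 3 gives the highest of the three numbers; compound 1 lies within the scatter of it, compound 2 lies well below it. Among the measured compounds shown here, the only measured step, a number 7.1 percentage points higher from compound 1 to compound 3 (within the scatter), concerns the alkoxy chain and does not touch the amide side. Compound 2 carries a different amide substituent and gives a far lower value than compound 1, but those two values alone cannot be read as a rule for amide substitution.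

Compound 4 `CCCCOc1cc(C(=O)NCCCN(C)C)nn1-c1ccccc1` differs from compound 3 by 2-(dimethylamino)ethyl in place of hydrogen on a saturated chain carbon bound to an amide-type nitrogen. For the measured compounds named here, no measured step covers this change, so the expectation rests on compound 3 alone and is uncertain. The step is expected to be a number 10 percentage points lower from compound 3 to compound 4 (within the scatter), and compound 4 is estimated at 55% (range 35% to 72%).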

Compound 4, a percentage reported as inhibition, in the whole organism at one dose (the size of the read-out at that dose, not a potency): 29.8%
Compound 4: the middle estimate sits 25.2 percentage points above what was measured; the whole stated range lies above it.
By their numbers in this assay, from the lowest: compounds 2 and 4 (each within the scatter of the next); then compounds 1 and 3 (each within the scatter of the next).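

Among the compounds shown here, the amide side of the series is sensitive in this assay: the change from methylamino to (3-(dimethylamino)propyl)amino gives a number 35.2 percentage points lower from compound 3 to compound 4 (beyond the scatter) and is the first single-place step beyond the scatter. The earlier step on the alkoxy chain stayed within the scatter, so among the single-place changes shown, only this one moves the read-out clearly. Nothing measured here accounts for the drop.

From the compounds shown here alone, it remains open whether the drop follows from the dimethylamino group or from the longer chain. A plain butyl chain or a morpholine-bearing propyl chain on the amide-type nitrogen would separate the two.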